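Adding a Second Chloro to a Level Set of Compounds

A few compounds are considered here, and "the series" means these few. Any claim that something is new, unique, unknown or untested is made for them only; others in the source may bear on it.

In a functional assay on MCF7 cells (Homo sapiens) for antiproliferative activity, read by MTT assay, with a stated time of 48 h (on this read-out higher numbers stand for weaker inhibition and lower numbers for stronger inhibition), compound 1 `O=C(/C=C/c1ccc(O)c(O)c1)N1CCN(c2ccccc2F)CC1` gives 1.38 ug/mL, compound 2 `O=C(/C=C/c1ccc(O)c(O)c1)N1CCN(c2ccccc2Cl)CC1` gives 1.36 ug/mL and compound 3 `O=C(/C=C/c1ccc(O)c(O)c1)N1CCN(c2cccc(Cl)c2)CC1` gives 1.34 ug/mL. Compound 3 therefore stands level with the other two, as all three values lie within the usual scatter of repeated measurements.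

Compound 4 `O=C(/C=C/c1ccc(O)c(O)c1)N1CCN(c2ccc(Cl)c(Cl)c2)CC1` differs from compound 3 by a single change: chloro in place of hydrogen on an aromatic carbon. This is chloro in place of hydrogen on an aromatic carbon, ortho to a chloro group and para to a large group, and it turns 3-chlorophenyl into 3,4-dichlorophenyl.

Among the measured compounds shown here, three measured steps bear on this change. Chloro in place of fluoro on an aromatic carbon gave a 1.0-fold lower number from compound 1 to compound 2 (0.01 log units; within the scatter). Exchanging 2-chlorophenyl for 3-chlorophenyl gave a 1.0-fold lower number from compound 2 to compound 3 (0.01 log units; within the scatter), and exchanging 2-fluorophenyl for 3-chlorophenyl gave a 1.0-fold lower number from compound 1 to compound 3 (0.01 log units; within the scatter). All three are very small, but none of them adds a second chloro, so they offer only indirect guidance and the range has to stay wide. No shift beyond the scatter is expected in this assay, and no direction can be favoured. The expected step is a 1.0-fold lower number from compound 3 to compound 4 (0.01 log units; within the scatter). For compound 4 the estimated value is 1.3 ug/mL, with an expected range from 0.7 ug/mL to 2.4 ug/mL.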

Compound 4, half-maximal inhibitory concentration: 1.28 ug/mL
Estimate against measurement, compound 4: 1.0-fold (0.01 log units) above; measured number inside the range.
By their numbers in this assay, from the lowest: compounds 4, 3, 2 and 1 (each within the scatter of the next).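

Among the compounds shown here, this is the first case here of a chloro added to a ring that already carries one, and in this assay the new chloro, ortho to a chloro group and para to a large group, gives a 1.0-fold lower number from compound 3 to compound 4 (0.02 log units; within the scatter). Set against the two compounds with a single halogen in other places on the ring, 3,4-dichlorophenyl gives a 1.1-fold lower number from compound 2 to compound 4 (0.03 log units; within the scatter) and a 1.1-fold lower number from compound 1 to compound 4 (0.03 log units; within the scatter), so this position accepts the extra chlorine with no shift that can be told apart from repeat measurements. Nothing in the data on hand speaks to the reason for this flat result.

The compounds shown carry only halogens on this ring, so they leave open whether a methoxy group, an amine or a carboxylic acid at the same position would stay as level as chloro does. Equally open, on these data alone, is whether a longer chain at this position, or a change elsewhere in the shared core, would move the number beyond the scatter.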